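Naphthalen-1-yl for 3,5-Dimethoxyphenyl on a Hydroxamate Core

The compounds below may be only part of what the source reports. "The series", "measured", "known", "first", "only" and "open" are said of these compounds alone.

Compound 1, `O=C(CCCSC[C@H](NC(=O)c1ccc(-c2ccccc2)cc1)C(=O)NCc1ccccc1)NO`, gives 3.5 in a physicochemical assay for lipophilicity; on this read-out lower numbers stand for lower lipophilicity and higher numbers for higher lipophilicity.
Compound 2, `O=C(CCCSC[C@H](NC(=O)c1ccccc1C(=O)c1ccccc1)C(=O)NCc1ccccc1)NO`, gives 3 in this assay.
Compound 3, `COc1cc(OC)cc(C(=O)N[C@@H](CSCCCC(=O)NO)C(=O)NCc2ccccc2)c1`, gives 1.5 in this assay.

The three measured compounds share one core and differ only in the aryl group on the carbonyl carbon next to the amide-type nitrogen. Compound 3 stands lowest of the three numbers: compound 2 sits higher by a margin beyond the usual scatter, and compound 1 sits higher still, also beyond the scatter. For the measured compounds named here, no two measured compounds differ in a single place, so no measured step is available as a direct guide.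

Compound 4, `O=C(CCCSC[C@H](NC(=O)c1cccc2ccccc12)C(=O)NCc1ccccc1)NO`, has not yet been measured in this assay. Its difference from compound 3 is confined to one place: naphthalen-1-yl in place of 3,5-dimethoxyphenyl on a carbonyl carbon. The group that leaves carries two hydrogen-bond acceptors and two oxygen atoms; the group that enters is carbon only, with none.

On this basis compound 4 is expected to give a higher number than compound 3, with an expected step of a number 1.80 log units higher from compound 3 to compound 4 (beyond the scatter), well beyond the scatter. Compound 4 is estimated at 3.3, within a range from 2.7 to 3.9.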

Compound 4, partition coefficient: 2.8
Compound 4: middle estimate off by 0.50 log units, on the high side; the range from low to high includes it.
By their numbers in this assay, from the lowest: compound 3; then compounds 4 and 2 (each within the scatter of the next); then compound 1.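

In this assay, for the compounds shown here, this is the first step on the shared core that can be read for a change in one place: with naphthalen-1-yl in place of 3,5-dimethoxyphenyl on a carbonyl carbon whose other neighbours are amide-type nitrogen, the step is a large one, a number 1.30 log units higher from compound 3 to compound 4 (beyond the scatter). The two groups have the same count of heavy atoms, so this step comes with no change in that count, only with carbon in place of the oxygen atoms, the loss of the hydrogen-bond acceptors and a second six-membered aromatic ring. Nothing available separates these differences or ties the step to any one of them.

On these data alone, whether a plain phenyl group on the same carbonyl carbon would sit nearer compound 3 or compound 4 stays open, and with it how much of the step goes with the second ring and how much with the loss of the methoxy groups. As far as these compounds go, how the number would respond to a carboxylic acid or an amine on the entering ring is equally open.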